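Moving the Trifluoromethyl on a Sulfonyl Analogue

A few compounds are considered here, and "the series" means these few. Any claim that something is new, unique, unknown or untested is made for them only; others in the source may bear on it.

The series comprises four compounds built on a common amide-bearing core. Compound 1 `CC(O)(CSc1cccc(C(F)(F)F)c1)C(=O)Nc1ccc(S(F)(F)(F)(F)F)cc1` and compound 2 `CC(O)(CSc1ccccc1C(F)(F)F)C(=O)Nc1ccc(S(F)(F)(F)(F)F)cc1` carry the aryl group on a sulfur, while compound 3 `CC(O)(CS(=O)(=O)c1cccc(C(F)(F)F)c1)C(=O)Nc1ccc(S(F)(F)(F)(F)F)cc1` and the unmeasured compound 4 `CC(O)(CS(=O)(=O)c1ccccc1C(F)(F)F)C(=O)Nc1ccc(S(F)(F)(F)(F)F)cc1` carry it on a sulfonyl sulfur. The difference between the core of compound 1 and the core of compound 3 is not broken down here.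

In a functional assay on LNCaP cells (Homo sapiens) for antiproliferative activity, read by propidium iodide staining, with a stated time of 96 h (a lower number here means a stronger inhibitor, a higher number a weaker inhibitor), compound 1 gives 18300 nM, and compound 2 gives 12300 nM. The change between them is 2-(trifluoromethyl)phenyl in place of 3-(trifluoromethyl)phenyl on a sulfur, and it produced a 1.5-fold lower number from compound 1 to compound 2 (0.17 log units; within the scatter). In this assay compound 3 gives 21000 nM, a number within the scatter of both compound 1 and compound 2.

Compound 4 differs from compound 3 by 2-(trifluoromethyl)phenyl in place of 3-(trifluoromethyl)phenyl on a sulfonyl sulfur. Within the data shown here, this is the same kind of change as the one from compound 1 to compound 2, but not the same: in the first pair the place is on a sulfur whose other neighbours are a saturated chain carbon, whereas here it is on a sulfonyl sulfur whose other neighbours are a saturated chain carbon. Among the measured compounds shown here, because the only precedent, a 1.5-fold lower number from compound 1 to compound 2 (0.17 log units; within the scatter), stayed within the scatter, the step from compound 3 to compound 4 in this assay is expected to be of similar small size, a 1.4-fold lower number from compound 3 to compound 4 (0.15 log units; within the scatter). On that basis compound 4 is estimated to give 15000 nM in this assay, with the expected range running from 7000 nM to 30000 nM.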

Compound 4, half-maximal inhibitory concentration: 10800 nM
Estimate against measurement, compound 4: 1.4-fold (0.14 log units) above, within the range that was stated.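

In this assay, the step on the sulfonyl sulfur is a 1.9-fold lower number from compound 3 to compound 4 (0.29 log units; within the scatter), and it can be set beside the matching step on the other sulfur, with the two agreeing in size: the same change on two cores in this assay, a 1.5-fold lower number (0.17 log units; within the scatter) from compound 1 to compound 2 and a 1.9-fold lower number (0.29 log units; within the scatter) from compound 3 to compound 4, 1.3-fold (0.12 log units) apart, within the scatter of two such steps. So far as these two pairs can tell, 2-(trifluoromethyl)phenyl in place of 3-(trifluoromethyl)phenyl behaves alike on the core of compound 1 and the core of compound 3, with no sign that the core alters the outcome of the change. This does not show that the change has a real effect on either core, as each step on its own lies within the scatter, and two pairs cannot say how the change would behave on any other core in the series.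

The compounds shown leave open how the aryl group would respond to a different substituent, such as a chlorine or a nitrile in place of the trifluoromethyl, on either sulfur. They also leave open what would happen to these numbers if the hydroxyl on the shared core gave way to an amine, or if a longer chain stood between that core and the sulfur.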